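The compounds below may be only part of what the source reports. "The series", "measured", "known", "first", "only" and "open" are said of these compounds alone.

Compound 1, `CCCCN1C(=O)/C(=C\C(=O)C[C@@H]2O[C@H](COC(C)=O)[C@@H](OC(C)=O)[C@H](OC(C)=O)[C@H]2OC(C)=O)c2cc(Cl)ccc21`, in an ADME assay on Vero cells (Chlorocebus sabaeus) for cytotoxicity, read by resazurin assay, with a stated time of 72 h (on this read-out lower numbers stand for higher toxicity in this test and higher numbers for lower toxicity in this test), gives 88900 nM. Compound 2, `CC(=O)OC[C@H]1O[C@@H](CC(=O)/C=C2\C(=O)N(Cc3ccccc3)c3ccc(Cl)cc32)[C@H](OC(C)=O)[C@@H](OC(C)=O)[C@@H]1OC(C)=O`, gives 91200 nM. Compound 3, `CC(=O)OC[C@H]1O[C@@H](CC(=O)/C=C2\C(=O)N(Cc3ccc(F)cc3)c3ccc(Cl)cc32)[C@H](OC(C)=O)[C@@H](OC(C)=O)[C@@H]1OC(C)=O`, gives 107000 nM.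

Compound 3 carries the highest of the three numbers as written, but a 1.2-fold higher number from compound 1 to compound 3 (0.08 log units; within the scatter) and a 1.2-fold higher number from compound 2 to compound 3 (0.07 log units; within the scatter) both lie within the scatter, so the three compounds sit level in this assay. Compound 4, `CC(=O)OC[C@H]1O[C@@H](CC(=O)/C=C2\C(=O)N(Cc3cccc(C)c3)c3ccc(Cl)cc32)[C@H](OC(C)=O)[C@@H](OC(C)=O)[C@@H]1OC(C)=O`, differs from compound 3 in one place: 3-methylphenyl in place of 4-fluorophenyl on a saturated chain carbon bound to an amide-type nitrogen in a ring. For the measured compounds named here, the steps that bear on it are a 1.0-fold higher number from compound 1 to compound 2 (0.01 log units; within the scatter) and a 1.2-fold higher number from compound 2 to compound 3 (0.07 log units; within the scatter), both small exchanges at the same place or on that ring, neither beyond the scatter. A step of like size, within the scatter and in no fixed direction, is therefore expected here, a 1.1-fold lower number from compound 3 to compound 4 (0.03 log units; within the scatter). Compound 4 is estimated at 100000 nM, between 55000 nM and 180000 nM.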

Compound 4, half-maximal cytotoxic concentration: 91000 nM
Estimate against measurement, compound 4: 1.1-fold (0.04 log units) above, within the range that was stated.
By their numbers in this assay, from the lowest: compounds 1, 4, 2 and 3 (each within the scatter of the next).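

At this position, on a saturated chain carbon bound to an amide-type nitrogen in a ring, 3-methylphenyl in place of 4-fluorophenyl gives a small step (a 1.2-fold lower number from compound 3 to compound 4 (0.07 log units; within the scatter)) in this assay. The methyl group alone (a 1.0-fold lower number from compound 2 to compound 4 (0.00 log units; within the scatter)) and 3-methylphenyl in place of propyl (a 1.0-fold higher number from compound 1 to compound 4 (0.01 log units; within the scatter)) change no more, so a methyl group on the aromatic ring, new with this compound, leaves all four compounds level. Nothing measured here gives a reason for this level picture. On these data alone, whether an amine or a carboxylic acid on that aromatic ring, or a longer chain in place of propyl, would move the number beyond the scatter remains open.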